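The source may report more compounds than this note shows. Statements on the series, on what has been measured and on what is new or still open speak of the compounds shown alone.

In a functional assay on Jurkat cells (Homo sapiens) for cytotoxicity, read by luminescence and CellTiter-Glo, with a stated time of 3 days (a higher number here means a weaker inhibitor, a lower number a stronger inhibitor), compound 1 `O=C(Nc1ccc(OC(F)(F)F)cc1)c1cc(F)ccc1O` gives 810 nM.
In this assay compound 2 `O=C(Nc1ccc(C(F)(F)F)cc1)c1cc(F)ccc1O` gives 580 nM.
In this assay compound 3 `O=C(Nc1ccc(OC(F)(F)F)c(Cl)c1)c1cc(Cl)ccc1O` gives 840 nM.

These three numbers sit close together, and none of the differences among them goes beyond what repeated measurements of this kind usually show. Compound 2 differs from compound 1 in a single place: trifluoromethyl in place of trifluoromethoxy on an aromatic carbon. In this assay this change produced a 1.4-fold lower number from compound 1 to compound 2 (0.15 log units; within the scatter), a step that counts as no real movement.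

Compound 4 `O=C(Nc1ccc(C(F)(F)F)c(Cl)c1)c1cc(Cl)ccc1O` has not yet been measured. It is obtained from compound 3 by the same kind of change: trifluoromethyl in place of trifluoromethoxy on an aromatic carbon. The surroundings of the exchanged group are not quite the same in the two pairs: in compound 3 the group sits ortho to a chloro group (1 heavy atom) as well as para to a large group, whereas in compound 1 it sits only para to a large group. How the core of compound 3 differs from the core of compound 1 is not broken down here; the two differ in more than one place.

The expectation for the new pair rests on the earlier pair. The step from compound 3 to compound 4 in this assay is estimated to be small, a 1.4-fold lower number from compound 3 to compound 4 (0.13 log units; within the scatter), because the same kind of change earlier gave a 1.4-fold lower number from compound 1 to compound 2 (0.15 log units; within the scatter). In this assay compound 4 is therefore expected to give about 620 nM, with the likely range running from 300 nM to 1300 nM.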

Compound 4, half-maximal inhibitory concentration: 690 nM
For compound 4 the middle estimate is 1.1-fold (0.05 log units) below the measured one; low and high end bracket the measured number.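

In this assay the exchange of trifluoromethoxy for trifluoromethyl on the second core gave a 1.2-fold lower number from compound 3 to compound 4 (0.09 log units; within the scatter), which again counts as no real movement. Set side by side, the two steps agree: the same change on two cores in this assay, a 1.4-fold lower number (0.15 log units; within the scatter) from compound 1 to compound 2 and a 1.2-fold lower number (0.09 log units; within the scatter) from compound 3 to compound 4, 1.1-fold (0.06 log units) apart, within the scatter of two such steps. Within the data shown here, in this small set, then, the exchange carries over from the core of compound 1 to the core of compound 3 with the same small outcome, even though the group on the second core sits ortho to a chloro group; this shows only that the two groups can stand in for each other in these two pairs, and it gives neither a general rule for the series nor any reason for the agreement.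

The compounds shown leave open whether other groups in the same place, such as a nitrile, an amine, a carboxylic acid or a longer chain, would also leave the number where it is. They also leave open what each chloro group contributes alone, as the core of compound 1 and the core of compound 3 differ in more than one place, so that a pair differing only in a single chloro group would be needed to separate them.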